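The compounds below may be only part of what the source reports. "The series", "measured", "known", "first", "only" and "open" are said of these compounds alone.

Measured compounds:

Compound 1 `Cc1ccc2[nH]c(=O)c(CN(Cc3ccccc3)Cc3ccc(C(C)(C)C)cc3)cc2c1`; in a toxicity assay on MDCK cells (Canis lupus familiaris) for cytotoxicity, read by crystal violet staining, with a stated time of 48 h (a lower number here means that less compound is tolerated, a higher number that more compound is tolerated), compound 1 gives > 5000 nM, which is a limit of the assay rather than a number.

Compound 2 `CCc1ccc2[nH]c(=O)c(CN(Cc3ccc(F)cc3)Cc3ccc(C(C)(C)C)cc3)cc2c1`; compound 2 gives > 33000 nM, again a limit.

Compound 3 `Cc1ccc2cc(CN(Cc3ccc(C(C)(C)C)cc3)CC3CCCCC3)c(=O)[nH]c2c1`; compound 3 gives > 10000 nM, also a limit.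

All three compounds share one core, and none of them produced a measurable number in this assay. Compound 1 stands at the limit of > 5000 nM in this assay, at which 1 of the 3 values shown sits, the lowest of the three limits. The others sit at the limit of > 10000 nM in this assay, at which 1 of the 3 values shown sits, and at the limit of > 33000 nM in this assay, at which 1 of the 3 values shown sits. Because each value is only a limit, no order among the three can be read from them; each compound was tolerated at least up to the highest concentration tested for it.

Compound 4 `Cc1ccc2[nH]c(=O)c(CN(Cc3ccc(OC(F)F)cc3)Cc3ccc(C(C)(C)C)cc3)cc2c1` is the next compound to be tested in this assay. It differs from compound 1 in one place: difluoromethoxy in place of hydrogen on an aromatic carbon.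

For the measured compounds named here, no measured pair here differs in a single place, so there is no measured step to lean on. With every value shown being a limit, the expectation for compound 4 is again a limit, and no step beyond the usual scatter is expected: the step that the limit leaves unreadable from compound 1 to compound 4 is an estimate only. Compound 4 is estimated at 20000 nM, in the range 5000 nM to 100000 nM.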

Compound 4, half-maximal cytotoxic concentration: > 5000 nM
Compound 4 gave a limit, no number; the forecaster's own chance of this, stated with the estimate: 80%; the middle value lies beyond the limit too.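

Compound 1 and compound 4 each give only a limit in this assay, not a number, so the step between them cannot be read. The compounds shown leave open at what concentration any of them harms the cells, and whether difluoromethoxy in place of hydrogen on an aromatic carbon shifts that concentration at all.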